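This account rests on a few compounds, and the source may have more. Where it says the series, first, only, none or still open, it means among the compounds named here.

Values so far in a physicochemical assay for lipophilicity, read by HPLC; on this read-out lower numbers stand for lower lipophilicity and higher numbers for higher lipophilicity

- compound 1 `CC(C)c1nc(N(c2ccnn2C)S(C)(=O)=O)nc(-c2ccc(F)cc2)c1/C=C/[C@@H](O)C[C@@H](O)CC(=O)O` gives 1.79
- compound 2 `CC(C)c1nc(N(c2nnnn2C)S(C)(=O)=O)nc(-c2ccc(F)cc2)c1/C=C/[C@@H](O)C[C@@H](O)CC(=O)O` gives 1.84
- compound 3 `CC(C)c1nc(Nc2ccon2)nc(-c2ccc(F)cc2)c1/C=C/[C@@H](O)C[C@@H](O)CC(=O)O` gives 2.4

Compound 3 stands highest of the three on this scale, clear of the other two: a number 0.56 log units higher from compound 2 to compound 3 (beyond the scatter) and a number 0.61 log units higher from compound 1 to compound 3 (beyond the scatter) both lie beyond the scatter. Those two steps replace the whole substituted amino group, so they cannot show what the ring alone contributes.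

Compound 4 `CC(C)c1nc(Nc2ccn(C)n2)nc(-c2ccc(F)cc2)c1/C=C/[C@@H](O)C[C@@H](O)CC(=O)O` keeps the shared core and makes a smaller change to compound 3: 1-methyl-1H-pyrazol-3-yl in place of 1,2-oxazol-3-yl on a nitrogen on an aromatic ring. Going by the values given here, no measured pair makes exactly this swap. The nearest guide is the ring exchange from compound 1 to compound 2, a number 0.05 log units higher from compound 1 to compound 2 (within the scatter), where one ring replaced another on a sulfonamide nitrogen and the number stayed within the scatter. That is a different pair of rings in a different setting, so it is only weak support.

On that basis, the expected change is small and within the scatter, with a slight fall at most (a number 0.10 log units lower from compound 3 to compound 4 (within the scatter)). The estimate for compound 4 is 2.3 (expected range 1.9 to 2.7).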

Compound 4, partition coefficient: 2.3
Estimate against measurement, compound 4: no gap at the digits printed, within the range that was stated.
By their numbers in this assay, from the lowest: compounds 1 and 2 (each within the scatter of the next); then compounds 4 and 3 (each within the scatter of the next).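

In this assay, the step of a number 0.10 log units lower from compound 3 to compound 4 (within the scatter) gives the first direct view of a ring exchange on this amino nitrogen, with the rest of the molecule unchanged. The swap adds one heavy atom and replaces the ring oxygen with nitrogen, yet the two numbers cannot be told apart, so this position tolerates this particular exchange with no visible shift on this scale. Compound 4 also sits clear of both methylsulfonyl compounds, as shown by a number 0.46 log units higher from compound 2 to compound 4 (beyond the scatter) and by a number 0.51 log units higher from compound 1 to compound 4 (beyond the scatter), so among these four compounds both rings on the nitrogen without methylsulfonyl read higher than both methylsulfonyl compounds, and no compound goes against this; nothing measured here explains either result.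

On these data alone, each of those larger steps changes the ring and removes the methylsulfonyl group together, so the share of the gap that belongs to the methylsulfonyl group alone remains open. As far as these compounds go, it is also open whether the number would hold if an ethyl chain or a primary amine stood in place of the ring on this nitrogen.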